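The compounds below may be only part of what the source reports. "The series", "measured", "known", "first", "only" and "open" are said of these compounds alone.

Of the compounds shown here, three built on one shared core have been measured in a functional assay on MDA-MB-231 cells (Homo sapiens) for cytotoxicity, read by sulforhodamine B assay, with a stated time of 72 h; a higher number here means a weaker inhibitor of growth, a lower number a stronger inhibitor of growth. Compound 1 `O=C(Nc1ccccc1O)C1CCc2ccccc2N1` gives 5260 nM in this assay. Compound 3 `O=C(Nc1ccccc1C(F)(F)F)C1CCc2ccccc2N1C(=O)c1ccccc1Cl` gives 2530 nM. Compound 2 `CC(=O)N1c2ccccc2CCC1C(=O)Nc1cc(C(F)(F)F)cc(C(F)(F)F)c1` gives only a limit, > 70000 nM, the edge of what the assay reports rather than a number. That is the limit of > 70000 nM in this assay, at which 1 of the 3 values shown sits.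

Compound 4 `O=C(Nc1cc(C(F)(F)F)cc(C(F)(F)F)c1)C1CCc2ccccc2N1C(=O)c1ccccc1` has not yet been measured. It differs from compound 2 by phenyl in place of methyl on a carbonyl carbon. Compound 3, which also carries a benzoyl-type group, gives a number rather than a limit, so the step in this assay is expected to run downward, toward stronger growth inhibition, well beyond the scatter. Compound 4 is expected near 8000 nM, within a range from 2000 nM to 40000 nM. That expectation amounts to a step of an at least 8.7-fold lower number from compound 2 to compound 4 (0.94 log units; beyond the scatter).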

Compound 4, concentration for 50% growth inhibition: 2430 nM
Compound 4: middle estimate off by 3.3-fold (0.52 log units), on the high side; measured number inside the range.
By their numbers in this assay, from the lowest: compounds 4 and 3 (each within the scatter of the next); then compound 1. At a limit, above all of these: compound 2.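

In this assay, replacing acetyl with benzoyl on the carbonyl carbon bound to the amide-type nitrogen in a ring gives an at least 28-fold lower number from compound 2 to compound 4 (1.45 log units; beyond the scatter). Within the data shown here, this is the first comparison here between two compounds that differ in one place, and it shows that the group at this position can strongly change growth inhibition. Compound 2 gives a limit, not a number: the limit of > 70000 nM in this assay, at which 1 of the 4 values shown sits.

The compounds shown do not reveal whether the aromatic ring itself matters or whether added carbon alone would do. A longer chain, such as butanoyl, or a cyclohexanecarbonyl group could separate these two readings.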